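Vero cell cytotoxicity notes on a four-compound series

The source may report more compounds than this note shows. Statements on the series, on what has been measured and on what is new or still open speak of the compounds shown alone.

Three compounds of the series have been run in an ADME assay on Vero cells (Chlorocebus sabaeus) for cytotoxicity (on this read-out higher numbers stand for lower toxicity in this test and lower numbers for higher toxicity in this test), and none of them returned a number. Compound 1 `Cn1c(-c2ccc(NC(=O)CN3CCCC3)cc2)nc2cc(C(F)(F)F)ccc21` gives > 100000 nM, which is a limit of the assay. Compound 2 `O=C(O)CCC(=O)Nc1ccc(-c2nc3cc(C(F)(F)F)ccc3[nH]2)cc1` gives > 100000 nM, again a limit and not a measured value. Compound 3 `O=C(CN1CCCC1)Nc1ccc(-c2nc3ccccc3[nH]2)cc1` gives > 100000 nM, also a limit. Compound 3 therefore stands exactly where the other two stand, namely at the limit of > 100000 nM in this assay, at which 3 of the 3 values shown sit, and the data allow no ordering among the three.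

Compound 4 `O=C(CN1CCCC1)Nc1ccc(-c2nc3cc(C(F)(F)F)ccc3[nH]2)cc1` still awaits measurement in this assay. It differs from compound 3 by trifluoromethyl in place of hydrogen on an aromatic carbon. No step between two measured compounds covers this change, so any expectation must rest on the three limits shown. Compound 1 also carries a trifluoromethyl and in this assay gives > 100000 nM, a limit. The step that the limit leaves unreadable from compound 3 to compound 4 is expected to be none beyond the scatter, the reason being (the limit of > 100000 nM in this assay, at which 3 of the 3 values shown sit). Compound 4 is accordingly estimated at 150000 nM, with a range from 60000 nM to 400000 nM, and the most likely outcome is that the assay will once more report only a limit.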

Compound 4, half-maximal cytotoxic concentration: > 100000 nM
Compound 4: a limit, no number; the forecaster's own chance of this, stated with the estimate: 85%; the middle value is on the limit's open side.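

In this assay no step can be read from compound 1, compound 2 or compound 3 to compound 4, as all four give a limit and not a number: the limit of > 100000 nM in this assay, at which 4 of the 4 values shown sit.

The compounds shown leave open where any of them would fall beyond that limit, and so whether trifluoromethyl in place of hydrogen on an aromatic carbon changes this read-out at all.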